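Replacing cyclooctyl on the amide of compound 3

The source may hold more compounds than are shown below. What is called first, only, known or untested is meant among the compounds shown, and "the series" means these compounds.

Values in a functional assay on BaF3 cells (Mus musculus) for antiproliferative activity, read by CCK-8 assay and cell counting, with a stated time of 76 h; on this read-out lower numbers stand for stronger inhibition and higher numbers for weaker inhibition:
Compound 1 `COc1cc2nccc(Oc3ccc(Nc4nn(C)cc4C(=O)Nc4ccccc4)cc3)c2cc1C(N)=O`: > 10000 nM, a limit.
Compound 2 `COc1cc2nccc(Oc3ccc(Nc4nn(C)cc4C(=O)NC45CCC(CC4)CC5)cc3)c2cc1C(N)=O`: > 10000 nM, a limit.
Compound 3 `COc1cc2nccc(Oc3ccc(Nc4nn(C)cc4C(=O)NC4CCCCCCC4)cc3)c2cc1C(N)=O`: 3210 nM.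

Compound 3 is the only one of the three with a number. The other two stand at the limit of > 10000 nM in this assay, at which 2 of the 3 values shown sit. Compound 4 `COc1cc2nccc(Oc3ccc(Nc4nn(C)cc4C(=O)NCC4CCCO4)cc3)c2cc1C(N)=O` differs from compound 3 as follows: (oxolan-2-yl)methyl in place of cyclooctyl on an amide-type nitrogen. Two measured steps at the same amide-type nitrogen bear on this change. One is an at least 3.1-fold lower number from compound 1 to compound 3 (0.49 log units; beyond the scatter). The other is an at least 3.1-fold lower number from compound 2 to compound 3 (0.49 log units; beyond the scatter). Both steps arrive at cyclooctyl, so losing it is expected to reverse a modest gain, although neither step involves the entering group. The expected change is a 2.8-fold higher number from compound 3 to compound 4 (0.45 log units; beyond the scatter), towards weaker inhibition. For compound 4 the estimate is 9000 nM, with an expected range of 3000 nM to 30000 nM.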

Compound 4, half-maximal inhibitory concentration: > 10000 nM
Compound 4 ended at the assay's limit; the forecaster's own chance of this, stated with the estimate: 55%; at least 1.1-fold (0.04 log units) between middle value and limit.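

In this assay, an at least 3.1-fold higher number from compound 3 to compound 4 (0.49 log units; beyond the scatter) shows that the earlier drop is not confined to phenyl or the two-ring group: (oxolan-2-yl)methyl on this amide-type nitrogen also fails to keep the measurable inhibition seen with cyclooctyl. The steps from compound 1 and from compound 2 to compound 4 cannot be read, with limits at both ends. Compound 4 sits at a limit, not a number, so cyclooctyl remains the only group here with a measured value: the limit of > 10000 nM in this assay, at which 3 of the 4 values shown sit.

On these data alone, whether the oxygen or the ring size of the entering group matters stays open, and cyclopentylmethyl on this nitrogen would separate the two. As far as these compounds go, how closely the activity depends on cyclooctyl also stays open, and cycloheptyl would bear on that.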